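This account rests on a few compounds, and the source may have more. Where it says the series, first, only, none or still open, it means among the compounds named here.

Measured compounds:
compound 1, `CN(Cc1cc(C(F)(F)F)cc(C(F)(F)F)c1)C(=O)c1cccnc1-c1ccccc1`: 151 nM
compound 2, `O=C1c2c(-c3ccccc3F)cc(N3CCC(N4CCCC4)CC3)nc2OCCCN1Cc1cc(C(F)(F)F)cc(C(F)(F)F)c1`: 0.207 nM

In a functional assay on ileum for antagonist activity at Substance-P receptor (Cavia porcellus) (a lower number here means a stronger inhibitor, a higher number a weaker inhibitor), compound 2 holds the lower of the two numbers shown; compound 1, with its smaller core, sits far above it, and the gap between the two lies well beyond the scatter of this assay. Among the measured compounds shown here, no pair differing in one place has been measured, so the series so far gives no step of the kind that now follows.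

Compound 3, `Cc1ccccc1-c1cc(N2CCC(N3CCCC3)CC2)nc2c1C(=O)N(Cc1cc(C(F)(F)F)cc(C(F)(F)F)c1)CCCO2`, differs from compound 2 by methyl in place of fluoro on an aromatic carbon. For the measured compounds named here, nothing measured here says how such a swap moves this assay; with no comparable step available, the expectation is a change of no more than the scatter in either direction. Compound 3 is therefore estimated at 0.3 nM, within 0.08 nM to 1.2 nM, which means an expected step of a 1.4-fold higher number from compound 2 to compound 3 (0.16 log units; within the scatter).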

Compound 3, antagonist equilibrium constant: 0.21 nM
For compound 3 the middle estimate is 1.4-fold (0.15 log units) above the measured one; the measured number falls inside the stated range.
By their numbers in this assay, from the lowest: compounds 2 and 3 (each within the scatter of the next); then compound 1.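

In this assay, among the compounds shown here, the change from 2-fluorophenyl to 2-methylphenyl gives the only step that can be read, a 1.0-fold higher number from compound 2 to compound 3 (0.01 log units; within the scatter), so compound 2 and compound 3 cannot be told apart. At this place, on an aromatic carbon ortho to a large group, methyl and fluoro are therefore interchangeable in this read-out, at least for this pair. No supporting measurement accounts for this match.

As far as these compounds go, what remains open is how far that interchangeability extends: a plain phenyl, a 2-chlorophenyl or a 2-methoxyphenyl would show whether the number depends on the group at this place at all. From the compounds shown here alone, it is also open whether a larger group, such as ethyl or isopropyl, or an amine at the same place would read alike.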